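Adding a chloro group to compound 3: a solubility estimate

The compounds below may be only part of what the source reports. "The series", "measured", "known", "first", "only" and "open" are said of these compounds alone.

Of the compounds shown here, three sharing one core have been measured in an ADME assay on stomach for solubility, in simulated gastric fluid; a higher number here means a more soluble compound, a lower number a less soluble compound. Compound 1 `O=C(Nc1ccc(C(F)(F)F)cc1)N1CCOC2(CCN(C(=O)c3ccco3)CC2)C1` gives 75 ug/mL. Compound 2 `O=C(Nc1ccc(C(F)(F)F)cc1)N1CCOC2(CCN(C(=O)c3c(F)cccc3F)CC2)C1` gives 43 ug/mL. Compound 3 `O=C(Nc1ccc(C(F)(F)F)cc1)N1CCOC2(CCN(C(=O)c3ccccc3)CC2)C1` gives 62 ug/mL. Among these three numbers compound 3 holds the second highest place, but a 1.2-fold lower number from compound 1 to compound 3 (0.08 log units; within the scatter) and a 1.4-fold higher number from compound 2 to compound 3 (0.16 log units; within the scatter) both lie within the scatter, so the three compounds cannot be told apart on the numbers alone.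

Compound 4 `O=C(Nc1ccc(C(F)(F)F)cc1)N1CCOC2(CCN(C(=O)c3ccccc3Cl)CC2)C1` has not yet been measured in this assay. It differs from compound 3 in one place: chloro in place of hydrogen on an aromatic carbon. Among the measured compounds shown here, no measured pair shows exactly this change. The nearest guide is the swap at the same carbonyl carbon from compound 2 to compound 3, a 1.4-fold higher number from compound 2 to compound 3 (0.16 log units; within the scatter), which exchanges two halogen atoms on the ring for hydrogens without moving the number beyond the scatter; the swap from compound 1 to compound 3, a 1.2-fold lower number from compound 1 to compound 3 (0.08 log units; within the scatter), is equally small.

For compound 4 the step of a 1.2-fold lower number from compound 3 to compound 4 (0.09 log units; within the scatter) is therefore expected to stay within the scatter, leaning slightly lower because a 1.4-fold higher number from compound 2 to compound 3 (0.16 log units; within the scatter) points weakly that way for a halogenated ring. The estimate for compound 4 in this assay is 50 ug/mL, with a range from 25 ug/mL to 100 ug/mL.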

Compound 4, solubility: 10 ug/mL
The estimate for compound 4 lay 5.0-fold (0.70 log units) above the measured number; measured number outside the range, below it.
By their numbers in this assay, from the lowest: compound 4; then compounds 2, 3 and 1 (each within the scatter of the next).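

Among the first three compounds, exchanging the group on the carbonyl carbon never moved the number in this assay beyond the scatter, so this part of the molecule looked insensitive, yet one chloro group on the aromatic ring, ortho to a large group, gives a 6.2-fold lower number from compound 3 to compound 4 (0.79 log units; beyond the scatter) as the first step here beyond the scatter. The 2-chlorophenyl group also stands apart from the other groups at that carbonyl carbon, with a 4.3-fold lower number from compound 2 to compound 4 (0.63 log units; beyond the scatter) on replacing 2,6-difluorophenyl and a 7.5-fold lower number from compound 1 to compound 4 (0.88 log units; beyond the scatter) on replacing furan-2-yl, so a halogen on the ring does not by itself bring the drop: compound 2 carries fluoro groups and stays within the scatter of compound 3. No other measurement is available that would explain the drop.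

The compounds shown leave open whether the lower number belongs to chloro itself or to any group at this aromatic carbon: a methyl, a methoxy or an amine there would separate the two. They also leave open whether chloro on a different carbon of the ring would give a step of the same size.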